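From pentyl to 4-fluorophenyl on the shared core

The compounds below may be only part of what the source reports. "The series", "measured", "known", "first", "only" and "open" are said of these compounds alone.

Measured in a functional assay on MDA-MB-231 cells (Homo sapiens) for antiproliferative activity, read by MTT assay, with a stated time of 72 h; a higher number here means a weaker inhibitor, a lower number a stronger inhibitor:
Compound 1 `COc1cc(-c2nccn2C(C)C)cc(OC)c1OC`: > 100000 nM, a limit
Compound 2 `CCCCCn1ccnc1-c1cc(OC)c(OC)c(OC)c1`: 34200 nM
Compound 3 `COc1cc(-c2nccn2-c2ccc3[nH]ccc3c2)cc(OC)c1OC`: 4300 nM

Of the two true numbers, compound 2 holds the higher, 34200 nM, and compound 3 the lower, 4300 nM. Compound 4 `COc1cc(-c2nccn2-c2ccc(F)cc2)cc(OC)c1OC` differs from compound 2 by 4-fluorophenyl in place of pentyl on an aromatic nitrogen. Within the data shown here, the one measured step on this nitrogen is an at least 2.9-fold lower number from compound 1 to compound 2 (0.46 log units; beyond the scatter), which exchanges pentyl for isopropyl and involves no ring. Compound 3, which also bears a ring there, gives 4300 nM, so a lower number is expected in this assay. The estimated step is a 2.9-fold lower number from compound 2 to compound 4 (0.45 log units; beyond the scatter). For compound 4 the estimated value is 12000 nM, with an expected range from 3000 nM to 45000 nM.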

Compound 4, half-maximal inhibitory concentration: 38400 nM
Compound 4: the middle estimate sits 3.2-fold (0.51 log units) below what was measured; the measured number falls inside the stated range.
By their numbers in this assay, from the lowest: compound 3; then compounds 2 and 4 (each within the scatter of the next). At a limit, above all of these: compound 1.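

Placing an aromatic ring on this nitrogen does not by itself separate a compound from its chain-bearing counterpart: 4-fluorophenyl in place of pentyl gives a 1.1-fold higher number from compound 2 to compound 4 (0.05 log units; within the scatter), while compound 3, which also carries a ring there, gives 4300 nM. Replacing isopropyl with 4-fluorophenyl gives an at least 2.6-fold lower number from compound 1 to compound 4 (0.41 log units; beyond the scatter), much as pentyl did. That step rests on compound 1, whose value is a limit: the limit of > 100000 nM in this assay, at which 1 of the 4 values shown sits.

On these data alone, it remains open whether a phenyl ring bearing an amine or a hydroxyl, or a chain longer than pentyl, would differ from these groups on this nitrogen.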